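The source may hold more compounds than are shown below. What is called first, only, known or untested is meant among the compounds shown, and "the series" means these compounds.

In an ADME assay on MT2 cells (Homo sapiens) for cytotoxicity, read by MTT assay (a higher number here means that more compound is tolerated, a lower number that less compound is tolerated), compound 1, whose structure is `Clc1cccc(Cl)c1Cc1nnc(Nc2ccc(COCc3ccccn3)cc2)o1`, reaches only the upper limit of the measurement, reported as > 100000 nM; this is a limit of the method and not a number. The other compound in the study, compound 2 with the structure `[O-][n+]1ccc(OCc2ccc(Nc3ncc(Cc4c(F)cccc4F)o3)cc2Cl)cc1`, gives 1700 nM in this assay. Of the two values shown, one sits at the limit, namely compound 1, as the limit of > 100000 nM in this assay, at which 1 of the 2 values shown sits, records, while compound 2 stands well within the measurable range.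

Compound 3, with the structure `Clc1cccc(Cl)c1Cc1nnc(Nc2ccc(COCc3ccsc3)cc2)o1`, has not yet been measured. It differs from compound 1 in one place: thiophen-3-yl in place of pyridin-2-yl on a saturated chain carbon bound to an oxygen on a saturated carbon. The rest of the molecule, the shared core with its dichlorobenzyl arm and the ether linkage, is unchanged. The pyridin-2-yl group that leaves and the thiophen-3-yl group that enters are both small aromatic rings with a single hetero atom.

Among the compounds with values here, no measured step between two compounds is available to show how such a swap moves cytotoxicity. The expectation for the step from compound 1 to compound 3 is therefore none beyond the scatter, written as a number no higher from compound 1 to compound 3 (the limit leaves the size open). Compound 3 is estimated at 100000 nM, within a range from 40000 nM to 200000 nM, and it is expected most likely to end at the limit as well.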

Compound 3, half-maximal cytotoxic concentration: > 100000 nM
Compound 3: a limit, no number (the forecaster's own chance of this, stated with the estimate: 70%); the middle value lies on the limit itself.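

Compound 3, like compound 1, gives a limit and not a number in this assay, so putting thiophen-3-yl in place of pyridin-2-yl yields no step that can be read between them: the limit of > 100000 nM in this assay, at which 2 of the 3 values shown sit.

The compounds shown leave open how much of compound 1 or compound 3 is tolerated beyond that limit, and whether this swap changes it at all.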